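This account rests on a few compounds, and the source may have more. Where it says the series, first, only, none or still open, it means among the compounds named here.

Of the compounds shown here, three built on a shared core have been measured in an ADME assay on Caco-2 cells (Homo sapiens) for permeability, in the apical to basolateral direction; on this read-out higher numbers stand for higher permeability and lower numbers for lower permeability. Compound 1 `Cn1cncc1CN1CC(N(CC2CCN(C(=O)c3ccccc3)CC2)S(=O)(=O)c2ccccn2)Cc2cc(C#N)ccc21` gives 0.5 10^-6 cm/s. Compound 2 `CC(C)NC(=O)N1CCC(CN(C2Cc3cc(C#N)ccc3N(Cc3cncn3C)C2)S(=O)(=O)c2ccccn2)CC1` gives 0.6 10^-6 cm/s, and compound 3 `Cn1cncc1CN1CC(N(CC2CCN(C(=O)c3ccco3)CC2)S(=O)(=O)c2ccccn2)Cc2cc(C#N)ccc21` gives 0.5 10^-6 cm/s. Compound 2 stands at the top of these three numbers only nominally: the step of a 1.2-fold higher number from compound 1 to compound 2 (0.08 log units; within the scatter) and the step of a 1.2-fold lower number from compound 2 to compound 3 (0.08 log units; within the scatter) are both within the scatter, as is no change at the digits printed from compound 1 to compound 3 (within the scatter), so the three compounds cannot be told apart on this read-out.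

Compound 4 `Cn1cncc1CN1CC(N(CC2CCN(C(=O)Nc3ccc(Br)cc3)CC2)S(=O)(=O)c2ccccn2)Cc2cc(C#N)ccc21` is not yet measured. It differs from compound 2 in one place: 4-bromophenyl in place of isopropyl on an amide-type nitrogen. Among the measured compounds shown here, none of the measured steps touches this position; all three exchange the group on the carbonyl carbon, and each stayed within the scatter. The measured data therefore offer no direct guide to swapping isopropyl for 4-bromophenyl on the amide-type nitrogen, and what they do show is that changes at the outer end of this side chain have not moved the number.

On that basis compound 4 is expected to show no step beyond the scatter, no change at the digits printed from compound 2 to compound 4 (within the scatter). Compound 4 is estimated at 0.6 10^-6 cm/s, with a range from 0.3 10^-6 cm/s to 1.3 10^-6 cm/s.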

Compound 4, apparent permeability: 0.6 10^-6 cm/s
Beside the measured number, compound 4's estimate shows no gap at the digits printed, and the stated range covers the measured number.
By their numbers in this assay, from the lowest: compounds 1, 3, 2 and 4 (each within the scatter of the next).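

In this assay, the exchange on the amide-type nitrogen can now be read directly: 4-bromophenyl in place of isopropyl gives (no change at the digits printed from compound 2 to compound 4 (within the scatter)), so a group of 7 heavy atoms with one six-membered aromatic ring and a bromine cannot be told apart from one of 3 carbons with no ring. Read one bond further out, on the carbonyl carbon, (4-bromophenyl)amino in place of furan-2-yl gives (a 1.2-fold higher number from compound 3 to compound 4 (0.08 log units; within the scatter)), and in place of phenyl it gives (a 1.2-fold higher number from compound 1 to compound 4 (0.08 log units; within the scatter)), so the earlier finding that exchanges at the outer end of this side chain stay within the scatter now extends to all four compounds, with none going against it. No measurement shown here accounts for this result.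

The compounds shown leave open whether the number would stay within the scatter with a carboxylic acid or a primary amine on the amide-type nitrogen, or with a longer chain there. They also leave open what exchanges elsewhere on the shared core would do, as all four compounds differ only at this outer end.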